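A few compounds are considered here, and "the series" means these few. Any claim that something is new, unique, unknown or untested is made for them only; others in the source may bear on it.

Going by the values given here, in a functional assay on HepG2 cells (Homo sapiens) for antiproliferative activity, read by sulforhodamine B assay, with a stated time of 48 h (on this read-out lower numbers stand for stronger inhibition and higher numbers for weaker inhibition), compound 2 (`COc1ccc(/C=C/C(=O)c2ccccc2-c2ccc(F)nc2)cc1`) stands highest so far at 290 nM and compound 1 (`COc1ccc(/C=C/C(=O)c2ccccc2-c2ccc(F)cc2)cc1`) lies lower at 93 nM as the only other number. Compound 3 (`COc1ccc(/C=C/C(=O)c2ccccc2-c2cccnc2)cc1`) carries hydrogen in place of fluoro on an aromatic carbon. Among the compounds with values here, no measured step removes this fluoro alone. The nearest guide is a 3.1-fold higher number from compound 1 to compound 2 (0.49 log units; beyond the scatter) for 6-fluoropyridin-3-yl in place of 4-fluorophenyl, a modest step. The step expected in this assay is a 1.2-fold higher number from compound 2 to compound 3 (0.08 log units; within the scatter) and leans towards a slightly higher number, without going beyond the scatter. Compound 3 is estimated at 350 nM (expected range 120 nM to 1000 nM).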

Compound 3, half-maximal inhibitory concentration: 97 nM
For compound 3 the middle estimate is 3.6-fold (0.56 log units) above the measured one; the measured number lies below the stated range.
By their numbers in this assay, from the lowest: compounds 1 and 3 (each within the scatter of the next); then compound 2.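

In this assay, hydrogen in place of the fluoro next to the ring nitrogen gives a 3.0-fold lower number from compound 2 to compound 3 (0.48 log units; beyond the scatter), so the higher number of compound 2 goes with 6-fluoropyridin-3-yl rather than with the ring nitrogen alone. Without that fluoro, the pyridin-3-yl group cannot be told apart from 4-fluorophenyl, with a 1.0-fold higher number from compound 1 to compound 3 (0.02 log units; within the scatter) in this assay. Nothing available explains either step.

Still open, on these data alone, is how a chloro or an amine on this same carbon would compare with hydrogen and fluoro. As far as these compounds go, whether the fluoro effect would recur in a different series also remains open.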